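The source may report more compounds than this note shows. Statements on the series, on what has been measured and on what is new or still open speak of the compounds shown alone.

Compounds measured so far:
- compound 1, `CCc1nc2ccccc2n1CCCCOc1cccc(C)c1`: 19 uM
- compound 2, `FC(F)(F)c1nc2ccccc2n1CCCCOc1ccccc1`: "not determined" (no result reported)
- compound 3, `Cc1ccc2nc(C(C)O)n(CCCCOc3ccccc3)c2c1`: "not determined" (no result reported)

Among the measured compounds shown here, in an ADME assay on Vero cells (Chlorocebus sabaeus) for cytotoxicity, read by luminescence, with a stated time of 2 days (a lower number here means that less compound is tolerated, a higher number that more compound is tolerated), compound 1 gives 19 uM, the only number in this set. Compound 2 and compound 3 carry no result in this assay, so compound 1 stands alone, with nothing to compare against. Compound 4, `CCc1nc2ccccc2n1CCCCOc1cccnc1`, has not yet been measured. It differs from compound 1 in one place: pyridin-3-yl in place of 3-methylphenyl on an oxygen on a saturated carbon. For the measured compounds named here, no pair of measured compounds shows the effect of such a change in this assay, so the step can only be guessed. The author expects a modest step upward from compound 1 to compound 4, a 1.5-fold higher number from compound 1 to compound 4 (0.17 log units; within the scatter), possibly not beyond the scatter. Compound 4 is therefore estimated at 28 uM, within the range 12 uM to 60 uM.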

Compound 4, half-maximal toxic concentration: > 50 uM
Compound 4 was reported as a limit; the forecaster's own chance of this, stated with the estimate: 30%; at least 1.7-fold (0.25 log units) between middle value and limit.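

In this assay, among the compounds shown here, pyridin-3-yl in place of 3-methylphenyl gives the first readable step at this position, an at least 2.6-fold higher number from compound 1 to compound 4 (0.42 log units; beyond the scatter), so the group on this oxygen does change the read-out. For compound 4, the value > 50 uM is a limit of the assay and not a number. The step therefore rests on one pair and has no upper end: the limit of > 50 uM in this assay, at which 1 of the 4 values shown sits.

As far as these compounds go, whether phenyl, pyridin-4-yl or an amine on the same oxygen would give a similar step stays open. For the compounds shown here, compound 2 and compound 3 carry no numbers, so no steps involving them can be read.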